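Removing a Chloro Group from a Pyrazole Urea

The compounds below may be only part of what the source reports. "The series", "measured", "known", "first", "only" and "open" are said of these compounds alone.

Compound 1 `O=C(Nc1cccc(-n2cc(-c3ccncc3)c(-c3cc(O)cc(Cl)c3)n2)c1)Nc1ccc(Cl)c(C(F)(F)F)c1`: -39%
Compound 2 `COc1cc(Cl)cc(-c2nn(-c3cccc(NC(=O)Nc4ccc(Cl)c(C(F)(F)F)c4)c3)cc2-c2ccncc2)c1`: -28%

Among the measured compounds shown here, in a functional assay on MOLT-4 cells (Homo sapiens) for inhibition, read by sulforhodamine B assay, with a stated time of 48 h, tested at 100 uM (on this read-out lower numbers stand for a stronger effect and higher numbers for a weaker effect at the one concentration tested), compound 2 stands highest of the two numbers; the single measured step, a number 11 percentage points higher from compound 1 to compound 2 (beyond the scatter), lies beyond the scatter. Compound 3 `COc1cc(Cl)cc(-c2nn(-c3cccc(NC(=O)Nc4cccc(C(F)(F)F)c4)c3)cc2-c2ccncc2)c1` differs from compound 2 by hydrogen in place of chloro on an aromatic carbon. For the measured compounds named here, no measured step touches this change: the one known step concerns the methyl on the oxygen, not the chloro. With nothing to guide direction, the expected step is none beyond the scatter, a number 6 percentage points higher from compound 2 to compound 3 (within the scatter). Compound 3 is therefore estimated at -22%, within a range from -45% to 0%.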

Compound 3, a percentage reported as activity, at one concentration (the size of the read-out at that concentration, not a potency): -36%
Beside the measured number, compound 3's estimate is 14 percentage points above it, and the stated range covers the measured number.
By their numbers in this assay, from the lowest: compounds 1, 3 and 2 (each within the scatter of the next, the first and the last beyond it).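

In this assay, replacing the chloro of the 4-chloro-3-(trifluoromethyl)phenyl group with hydrogen, which leaves 3-(trifluoromethyl)phenyl, gives a number 8 percentage points lower from compound 2 to compound 3 (within the scatter). At this one concentration, then, the read-out does not distinguish the compound with the chloro from the one without it. No measurement at hand explains this result.

As far as these compounds go, it remains open how a bromo or an amine at this position would read. From the compounds shown here alone, it is also open whether losing the chloro would give a similar result in compound 1, which carries a hydroxyl where compound 2 has its methoxy.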